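Cytotoxicity limits and a 4-methoxyphenyl swap on compound 3

The source may report more compounds than this note shows. Statements on the series, on what has been measured and on what is new or still open speak of the compounds shown alone.

In an ADME assay on cells (Homo sapiens) for cytotoxicity, read by resazurin assay, with a stated time of 5 days (a lower number here means that less compound is tolerated, a higher number that more compound is tolerated), compound 3 `O=S(=O)(Cc1nc(-c2ccncc2)c2sccc2n1)c1cccc(Cl)c1` gives > 50000 nM, a limit of the assay and not a number. Compound 1 `COc1ccc(-c2nc(C(C)(C)S(=O)(=O)c3cccc(Cl)c3)nc3ccsc23)cn1` gives > 50000 nM, also a limit. Compound 2 `c1ccc(-c2cc(CNc3nncc(-c4cccc5ccccc45)n3)n[nH]2)cc1` gives > 10000 nM, again a limit. Among the measured compounds shown here, the series so far therefore holds only limits, with the limit of > 50000 nM in this assay, at which 2 of the 3 values shown sit, and (the limit of > 10000 nM in this assay, at which 1 of the 3 values shown sits). For the measured compounds named here, compound 3 has no number that could place it against the other two, and no pair of measured compounds differs in one place.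

Compound 4 `COc1ccc(-c2nc(CS(=O)(=O)c3cccc(Cl)c3)nc3ccsc23)cc1` differs from compound 3 at a single site, with 4-methoxyphenyl in place of pyridin-4-yl on an aromatic carbon, next to the ring nitrogen: 4-methoxyphenyl in place of pyridin-4-yl on an aromatic carbon. Going by the values given here, no measured step isolates this change, so any expectation rests on the limits alone. No step beyond the scatter is expected in this assay, in either direction. The expectation leans on compound 1, which also gives > 50000 nM, a limit of the assay. The estimated step of a number no higher from compound 3 to compound 4 (the limit leaves the size open) is correspondingly small, and a further limit is a likely outcome. The estimate for compound 4 is 50000 nM, with an expected range of 20000 nM to 100000 nM.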

Compound 4, half-maximal cytotoxic concentration: 69000 nM
Estimate against measurement, compound 4: 1.4-fold (0.14 log units) below; the measured number falls inside the stated range.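

In this assay compound 3 gives > 50000 nM, a limit of the assay and not a number. Compound 4 gives 69000 nM, so no step can be read between the two compounds. The compounds shown leave open whether 4-methoxyphenyl in place of pyridin-4-yl changes the tolerated concentration at all.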